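This account rests on a few compounds, and the source may have more. Where it says the series, first, only, none or still open, it means among the compounds named here.

Measured so far:
- compound 1, `CCOc1ccc2[nH]c(-c3ccc(OC)cc3)c(C3=C(Br)C(=O)NC3=O)c2c1`, gives 2.77 in a physicochemical assay for lipophilicity; on this read-out higher numbers stand for higher lipophilicity and lower numbers for lower lipophilicity.
- compound 2, `CCOc1ccc2[nH]c(-c3cccc(OC)c3)c(C3=C(Br)C(=O)NC3=O)c2c1`, gives 2.97 in this assay.

Among these two numbers compound 2 stands highest, with compound 1 nearest, but the gap between them is within the scatter, so the two cannot be told apart with confidence. For the measured compounds named here, the only measured step, a number 0.20 log units higher from compound 1 to compound 2 (within the scatter), came from a 3-methoxyphenyl in place of a 4-methoxyphenyl on an aromatic carbon.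

Compound 3, `CCCCc1ccc2[nH]c(-c3cccc(OC)c3)c(C3=C(Br)C(=O)NC3=O)c2c1`, has not been measured yet. It differs from compound 2 in one place: butyl in place of ethoxy on an aromatic carbon. Going by the values given here, no measured step concerns this kind of change; the step between compound 1 and compound 2 touched a different part of the molecule and does not bear on it. The expectation therefore rests on the structural change alone, as described, and on general experience with such exchanges. A clear rise in this assay is expected, estimated as a number 1.33 log units higher from compound 2 to compound 3 (beyond the scatter). For compound 3 the estimated value is 4.3, with a range from 3.7 to 4.9.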

Compound 3, partition coefficient: 3.81
Beside the measured number, compound 3's estimate is 0.49 log units above it; measured number inside the range.
By their numbers in this assay, from the lowest: compounds 1 and 2 (each within the scatter of the next); then compound 3.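

In this assay, butyl in place of ethoxy on this aromatic carbon of the shared core gives a number 0.84 log units higher from compound 2 to compound 3 (beyond the scatter), the only step among these compounds printed as beyond the scatter. For the compounds shown here, the earlier step moved a methoxy group on the other aromatic ring and stayed within the scatter, so this position is the first place where a single change clearly separates two compounds on this read-out. The change replaces ethoxy, which contains oxygen and counts 1 hydrogen-bond acceptor, with butyl, which contains only carbon and counts 0, but no measurement here explains the size of the step.

Butyl differs from ethoxy both in lacking the oxygen and in having a longer chain, so the compounds shown leave open how much of the step belongs to each difference. Also open, from the compounds shown here alone, are how the same position would respond to propyl, to a longer chain such as hexyl, or to an amine or a carboxylic acid, and whether butyl would give a similar step alongside the 4-methoxyphenyl group of compound 1.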